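This account rests on a few compounds, and the source may have more. Where it says the series, first, only, none or still open, it means among the compounds named here.

Compound 1 `COc1ccc(-c2cc(NC(=O)C(Cl)Cl)cc(-c3ccc(OC)cc3)c2)cc1`: > 30000 nM, a limit of the assay
Compound 2 `COc1ccc(-c2cccc(NC(=O)C(Cl)Cl)c2)cc1`: 43300 nM
Compound 3 `CCOc1ccc(-c2cc(NC(=O)C(Cl)Cl)cc(-c3ccc(OCC)cc3)c2)cc1`: 6080 nM

All three compounds were tested in a functional assay on NCI-H460 cells (Homo sapiens) for cytotoxicity, read by MTT assay, with a stated time of 68 h; on this read-out lower numbers stand for stronger inhibition and higher numbers for weaker inhibition. Compound 2 gives 43300 nM, the higher of the two readable numbers. Compound 3 gives 6080 nM, lower by a margin beyond the scatter. The third result gives no number, as compound 1 stands at the limit of > 30000 nM in this assay, at which 1 of the 3 values shown sits.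

Compound 4 `O=C(Nc1cccc(-c2ccc(Cl)cc2)c1)C(Cl)Cl` departs from compound 2 by a single change, (chloro in place of methoxy on an aromatic carbon), chloro in place of methoxy on an aromatic carbon, para to a large group. Within the data shown here, the only measured step, a step that the limit leaves unreadable from compound 1 to compound 2, concerns a different change and offers no size to carry over. Among the measured compounds shown here, no measured step shows this exchange, so no direction can be drawn from the data, and the expectation stays anchored on compound 2 at 43300 nM. The expected change is a 1.4-fold lower number from compound 2 to compound 4 (0.16 log units; within the scatter), which stays within the scatter. For compound 4 the estimated value is 30000 nM, with an expected range from 10000 nM to 80000 nM.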

Compound 4, half-maximal inhibitory concentration: > 50000 nM
Compound 4 gave a limit, no number; the forecaster's own chance of this, stated with the estimate: 20%; at least 1.6-fold (0.22 log units) between middle value and limit.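

Among these compounds, the exchange of methoxy for chloro on this aromatic carbon, para to a large group, gives the first step at this position that can be read at all, though only in one direction: an at least 1.1-fold higher number from compound 2 to compound 4 (0.06 log units; that floor lies within the scatter). In this assay, among the compounds shown here, the floor of that step stays within the scatter, so the data show only that this change did not bring the number down, and they do not show how far it may have risen. Compound 4 stands at a limit of the assay, not at a number: the limit of > 50000 nM in this assay, at which 1 of the 4 values shown sits.

On these data alone, how far the number lies from that of compound 2 therefore stays open, as does whether chloro would read the same way on the core of compound 1. Also open, as far as these compounds go, is how an amine or a carboxylic acid would read at this same position.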